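The source may hold more compounds than are shown below. What is called first, only, known or untested is meant among the compounds shown, and "the series" means these compounds.

In a functional assay, read by spectrophotometry, with a stated time of 30 min (a lower number here means a stronger inhibitor, a higher number a weaker inhibitor), compound 1 `CC(C)(C)c1cc(CCC(=O)NCC2CCN(Cc3ccccc3)CC2)cc(C(C)(C)C)c1O` gives 63400 nM as its half-maximal inhibitory concentration. Compound 2 `CC(C)(C)c1cc(/C=C/C(=O)NC2CCN(Cc3ccccc3)CC2)cc(C(C)(C)C)c1O` gives 71900 nM on the same read-out. Compound 3 `CC(C)(C)c1cc(/C=C/C(=O)NCCC2CCN(Cc3ccccc3)CC2)cc(C(C)(C)C)c1O` gives 81700 nM and so stands within the scatter of both compound 1 and compound 2. The three numbers therefore show no real separation. No two of these compounds differ in one place only, so they offer no direct measure of any single structural change.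

Compound 4 `CC(C)(C)c1cc(/C=C/C(=O)NCCC2CCN(Cc3cccc(F)c3)CC2)cc(C(C)(C)C)c1O` departs from compound 3 in one place (fluoro in place of hydrogen on an aromatic carbon), with fluoro in place of hydrogen on an aromatic carbon, which turns benzyl to 3-fluorobenzyl. Among the measured compounds shown here, with no measured example of this change, the expectation rests on compound 3 at 81700 nM as its starting point, and the range is kept wide. The estimated change a 1.3-fold lower number from compound 3 to compound 4 (0.10 log units; within the scatter) is expected to stay within the scatter, leaning only slightly toward a lower number, and that direction is not firmly supported by the data. For compound 4 the expected value is 65000 nM within an estimated range of 25000 nM to 130000 nM in this assay once it is measured.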

Compound 4, half-maximal inhibitory concentration: 55200 nM
The estimate for compound 4 lay 1.2-fold (0.07 log units) above the measured number, and the stated range covers the measured number.
By their numbers in this assay, from the lowest: compounds 4, 1, 2 and 3 (each within the scatter of the next).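

In this assay, among the compounds shown here, the change from benzyl to 3-fluorobenzyl provides the first comparison in this set between two compounds that differ in one place only, and it reads as a 1.5-fold lower number from compound 3 to compound 4 (0.17 log units; within the scatter). A single fluoro on this aromatic carbon, the only heavy atom that enters, therefore does not separate compound 4 from compound 3 on this read-out, so the assay draws no real distinction between the two benzyl groups at this position. No measurement shown here bears on this result or offers any account of it.

The compounds shown leave open whether a group other than fluoro at this position, such as chloro, methoxy, trifluoromethyl or an amine, would move the number beyond the scatter, and whether fluoro on another carbon of the same ring would do so. They also leave open what the saturated chain of compound 1 and the different chain lengths of compounds 1, 2 and 3 contribute, since those compounds differ from one another in more than one place.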